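Methoxyphenyl amide on the chloro core: expected at limit

The source may report more compounds than this note shows. Statements on the series, on what has been measured and on what is new or still open speak of the compounds shown alone.

Compound 3 `O=C(Nc1ccc(Sc2nc3ccccc3s2)c(Cl)c1)c1cc(Br)cc(Br)c1O` gives only the limit of an assay on isolated protein for inhibition of thiosulfate sulfurtransferase (Homo sapiens), with a stated time of 60 min, in the absence of a further agent; a lower number here means a stronger inhibitor, a higher number a weaker inhibitor: its value > 100000 nM is a limit of the assay and not a number. Compound 1 `O=C(Nc1ccc(Sc2nc3ccccc3s2)c(Cl)c1)c1cc(Br)cc(Br)c1` also reaches only the limit, > 100000 nM in this assay. Compound 2 `COc1ccccc1C(=O)Nc1ccc(Sc2nc3ccccc3s2)cc1` in turn gives the limit > 100000 nM in this assay. The step from compound 1 to compound 3 is a step that the two limits leave unreadable from compound 1 to compound 3 and cannot be read, since the limit of > 100000 nM in this assay, at which 3 of the 3 values shown sit, holds for both. Compound 4 `COc1ccccc1C(=O)Nc1ccc(Sc2nc3ccccc3s2)c(Cl)c1` differs from compound 3 by 2-methoxyphenyl in place of 3,5-dibromo-2-hydroxyphenyl on a carbonyl carbon. Among the compounds with values here, no measured step reads this change directly; compound 2, which bears the same 2-methoxyphenyl on the carbonyl carbon, stays at the limit. Compound 4 is therefore expected to remain at the limit, the estimated step from compound 3 to compound 4 being a step that the limit leaves unreadable from compound 3 to compound 4. The estimate for compound 4 in this assay is 200000 nM, with a range from 100000 nM to 1000000 nM.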

Compound 4, half-maximal inhibitory concentration: > 100000 nM
Compound 4 ended at the assay's limit; the forecaster's own chance of this, stated with the estimate: 90%; the middle value is on the limit's open side.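

No step to compound 4 from compound 1, compound 2 or compound 3 can be read in this assay, since each value is a limit and not a number: the limit of > 100000 nM in this assay, at which 4 of the 4 values shown sit.

The compounds shown leave open which change to the shared core, if any, would bring a readable value.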